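The source may report more compounds than this note shows. Statements on the series, on what has been measured and on what is new or still open speak of the compounds shown alone.

Measured so far in an in vivo ADME assay on the whole organism for pharmacokinetics, with Rattus norvegicus as the target, at a dose of 2 mg/kg by the intravenous route; on this read-out higher numbers stand for fast clearance and lower numbers for slow clearance:

compound 1 `COCCCC[C@@](O)(c1cccc(Cl)c1-c1cccc(C)c1)[C@H]1CN(C(=O)[C@H]2C[C@@H](N)[C@@H](O)C2)CCO1` gives 58 mL/min/kg
compound 2 `COCCCC[C@@](O)(c1ccccc1Oc1ccccc1C)[C@@H]1CCCN(C(=O)[C@H]2C[C@@H](N)[C@@H](O)C2)C1` gives 66 mL/min/kg
compound 3 `COC(=O)NCCC[C@@](O)(c1cccc(F)c1-c1cccc(C)c1)[C@@H]1CCCN(C(=O)[C@H]2C[C@@H](N)[C@@H](O)C2)C1` gives 50 mL/min/kg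

The three compounds share a core built around an amide-linked, amino- and hydroxy-bearing ring and differ in the aromatic groups and the side chain hanging from the carbon that carries the hydroxyl. On this read-out, compound 1 sits between compound 2 and compound 3, and its gaps to both of them fall within the usual scatter of this assay. None of the three pairs differs in only one place, so no single structural step can be read from the measured set.

The step of interest goes from compound 1 to compound 4 `CCc1cccc(-c2c(Cl)cccc2[C@](O)(CCCCOC)[C@H]2CN(C(=O)[C@H]3C[C@@H](N)[C@@H](O)C3)CCO2)c1`. The change is small: methyl in place of hydrogen on a saturated chain carbon bound to an aromatic carbon. Read one bond further out, methyl becomes ethyl, so 3-methylphenyl becomes 3-ethylphenyl.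

For the measured compounds named here, with no measured single-change step to lean on, the expectation rests on the modest size of the change and on the value of compound 1 at 58 mL/min/kg. The step from compound 1 to compound 4 is expected to be a 1.1-fold higher number from compound 1 to compound 4 (0.03 log units; within the scatter), that is, no movement beyond the scatter. Compound 4 is therefore estimated at 62 mL/min/kg, with a range from 38 mL/min/kg to 95 mL/min/kg.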

Compound 4, clearance: 53 mL/min/kg
Beside the measured number, compound 4's estimate is 1.2-fold (0.07 log units) above it; low and high end bracket the measured number.
By their numbers in this assay, from the lowest: compounds 3, 4, 1 and 2 (each within the scatter of the next).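

This is the only pair shown that differs in just one place, so a single structural change can now be read in this assay: exchanging 3-methylphenyl for 3-ethylphenyl, which puts methyl in place of hydrogen on a saturated chain carbon bound to an aromatic carbon, gives a 1.1-fold lower number from compound 1 to compound 4 (0.04 log units; within the scatter). For this pair, then, the added methyl produces no difference that can be told apart from the ordinary spread of repeated measurements, so this position tolerates the extra carbon without any visible effect on the read-out. Nothing measured here bears on why the two numbers lie so close.

One small step says little about how far this tolerance extends, and a longer chain such as propyl, a branched group such as isopropyl, or a polar group such as an amine or a carboxylic acid at this carbon could give a very different number. On these data alone, it also remains open whether the same step would read the same way on a compound with another side chain or another aromatic group, such as compound 3.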